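The compounds below may be only part of what the source reports. "The series", "measured", "known", "first", "only" and "open" are said of these compounds alone.

Measured in a functional assay on A-431 cells (Homo sapiens) for inhibition, read by sulforhodamine B assay, with a stated time of 2 days; on this read-out lower numbers stand for stronger inhibition of growth and higher numbers for weaker inhibition of growth:
- compound 1 `CC1=C(C(=O)Nc2ccc(C)cc2)C(c2ccc(O)cc2O)NC(NCc2ccccc2)=N1`: 42700 nM
- compound 2 `CC1=C(C(=O)Nc2cccc([N+](=O)[O-])c2)C(c2ccc(O)cc2O)NC(NCc2ccccc2)=N1`: 35600 nM
- compound 3 `CC1=C(C(=O)Nc2cccc([N+](=O)[O-])c2)C(c2ccc(O)cc2O)NC(Nc2ccc(S(=O)(=O)Nc3ncccn3)cc2)=N1`: 69200 nM

Compound 2 stands within the usual scatter of both compound 1 and compound 3, so this assay does not separate it from either. Compound 4 `CC1=C(C(=O)Nc2cccc([N+](=O)[O-])c2)C(c2ccc(O)cc2O)NC(N/N=C/c2ccco2)=N1` keeps the rest of compound 2 and exchanges the benzyl on the amine nitrogen: a group of 7 heavy atoms (5 carbon, 1 nitrogen, 1 oxygen; one five-membered aromatic ring with 1 hetero atom) in place of a group of 7 heavy atoms (7 carbon; one six-membered aromatic ring of carbon only), on an amine nitrogen.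

For the measured compounds named here, the one measured step, a 1.2-fold lower number from compound 1 to compound 2 (0.08 log units; within the scatter), concerns the amide-type nitrogen rather than this place, so it bears on the change only indirectly. Closer evidence comes from the pair that differs on the amine nitrogen: compound 2 gives 35600 nM and compound 3 gives 69200 nM, two values that also lie within the scatter of each other. Going by the values given here, no measured compound carries the entering group with its five-membered aromatic ring, so the evidence for it is thin. On these numbers, no shift beyond the scatter is expected in this assay, and no direction can be firmly predicted. The estimated change is a 1.1-fold higher number from compound 2 to compound 4 (0.05 log units; within the scatter). For compound 4 the expected value is 40000 nM, with an estimated range from 18000 nM to 90000 nM.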

Compound 4, concentration for 50% growth inhibition: 2910 nM
For compound 4 the middle estimate is 14-fold (1.14 log units) above the measured one; measured number below the stated range.
By their numbers in this assay, from the lowest: compound 4; then compounds 2, 1 and 3 (each within the scatter of the next).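

In this assay the amine nitrogen proves to be a place where the read-out responds: the change gives a 12-fold lower number from compound 2 to compound 4 (1.09 log units; beyond the scatter) and is the only step shown that lies beyond the scatter, whereas compound 2 and compound 3, which also differ at this nitrogen, stayed within the scatter of each other. The two groups have the same heavy-atom count, so that count alone does not follow the step; the entering group differs from benzyl in its five-membered aromatic ring with 1 hetero atom, its double bond outside aromatic rings and its 2 hydrogen-bond acceptors. Nothing available here shows which of these features accounts for the step, or why it occurs.

The compounds shown leave open whether the five-membered ring or the double-bonded nitrogen link matters more, a question that a thiophene ring on the same link, or a phenyl ring on it, would address. They also leave open whether the same exchange would give a similar step with 4-methylphenyl in place of 3-nitrophenyl on the amide-type nitrogen.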